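The source may hold more compounds than are shown below. What is called first, only, known or untested is meant among the compounds shown, and "the series" means these compounds.

Measured so far:
compound 1 `CCn1cnc2c(N)nc(N)nc21` — > 100000 nM
compound 2 `CC[C@@H](N)COc1nc(NC(=N)N)c2ncn(C(C)C)c2n1` — > 100000 nM

Compound 1 gives in a functional assay on MCF7 cells (Homo sapiens) for inhibition, read by fluorescence, with a stated time of 72 h (a lower number here means a stronger inhibitor, a higher number a weaker inhibitor), a value of > 100000 nM, which is a limit of the assay and not a number. Compound 2 likewise reports only a limit, > 100000 nM. Compound 2 thus stands at the limit of > 100000 nM in this assay, at which 2 of the 2 values shown sit. Compound 3, `CC(C)n1cnc2c(NC(=N)N)nc(N3CCC[C@H]3CO)nc21`, is not yet measured; the change is 2-(hydroxymethyl)pyrrolidin-1-yl in place of 2-aminobutoxy on an aromatic carbon. Within the data shown here, no measured step is known here, so the step is expected to stay within the scatter, a number no higher from compound 2 to compound 3 (the limit leaves the size open). Compound 3 is estimated at 100000 nM, in a range from 20000 nM to 500000 nM.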

Compound 3, half-maximal inhibitory concentration: 6200 nM
The estimate for compound 3 lay 16-fold (1.21 log units) above the measured number; the measured number lies below the stated range.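

In this assay, placing 2-(hydroxymethyl)pyrrolidin-1-yl instead of 2-aminobutoxy on this aromatic carbon, between two ring nitrogen atoms, gives an at least 16-fold lower number from compound 2 to compound 3 (1.20 log units; beyond the scatter). Among these compounds, the group at this position can therefore move the result from the assay limit to a measurable number, which the earlier compounds could not show. The full size of the step stays unknown because compound 2 has only a limit: the limit of > 100000 nM in this assay, at which 2 of the 3 values shown sit.

Going by these compounds, it remains open whether the ring or its hydroxymethyl matters more. A plain pyrrolidin-1-yl or a longer chain ending in an amine could help separate the two.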